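The compounds below may be only part of what the source reports. "The series", "measured", "known", "first", "only" and "open" are said of these compounds alone.

Working notes on the amide series.

Among the measured compounds shown here, compound 1 `CCCNC(=O)c1ccc(Oc2nc(-c3c(C)noc3C)cnc2N)cc1` gives 6880 nM in a functional assay on HepG2 cells (Homo sapiens) for inhibition, read by MTT assay, with a stated time of 72 h (on this read-out higher numbers stand for weaker inhibition and lower numbers for stronger inhibition), and shows the lowest of the three numbers measured so far, though the other two sit within the scatter of it. Compound 2 `Cc1noc(C)c1-c1cnc(N)c(Oc2ccc(C(=O)NC3CCCC3)cc2)n1` gives 12800 nM in this assay, and compound 3 `Cc1noc(C)c1-c1cnc(N)c(Oc2ccc(C(=O)Nc3ccccc3)cc2)n1` gives 11800 nM. The steps among them are small: a 1.9-fold higher number from compound 1 to compound 2 (0.27 log units; within the scatter), a 1.7-fold higher number from compound 1 to compound 3 (0.23 log units; within the scatter) and a 1.1-fold lower number from compound 2 to compound 3 (0.04 log units; within the scatter). None of them rises above the scatter, so changing the group on the amide-type nitrogen from propyl to cyclopentyl or to phenyl has so far left this assay essentially unmoved.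

Compound 4 `Cc1noc(C)c1-c1cnc(N)c(Oc2ccc(C(=O)Nc3cccc(Cl)n3)cc2)n1` is not yet measured. It differs from compound 1 as follows: 6-chloropyridin-2-yl in place of propyl on an amide-type nitrogen. For the measured compounds named here, the nearest precedent is the step from propyl to phenyl on the same nitrogen, which stayed within the scatter, and the phenyl-to-cyclopentyl comparison gives no sign of a larger effect either. For compound 4 the expected step is therefore a 1.3-fold higher number from compound 1 to compound 4 (0.12 log units; within the scatter), nothing beyond the scatter. Compound 4 is estimated at 9000 nM in this assay, within a range of 3500 nM to 25000 nM.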

Compound 4, half-maximal inhibitory concentration: 35700 nM
Compound 4: the middle estimate sits 4.0-fold (0.60 log units) below what was measured; measured number outside the range, above it.
By their numbers in this assay, from the lowest: compounds 1, 3 and 2 (each within the scatter of the next); then compound 4.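

The amide-type nitrogen, which looked indifferent across propyl, cyclopentyl and phenyl, does respond in this assay: 6-chloropyridin-2-yl gives steps beyond the scatter against all three earlier groups, with a 5.2-fold higher number from compound 1 to compound 4 (0.72 log units; beyond the scatter), a 2.8-fold higher number from compound 2 to compound 4 (0.45 log units; beyond the scatter) and a 3.0-fold higher number from compound 3 to compound 4 (0.48 log units; beyond the scatter). All three steps run towards weaker inhibition, so this position tolerates some groups without a readable change but not every group, and an aromatic ring on this nitrogen is not enough by itself to set the number, as phenyl and 6-chloropyridin-2-yl part here. No measurement at hand bears on the reason for this step.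

The compounds shown do not separate the ring nitrogen from the chlorine, which pyridin-2-yl and a chlorophenyl group would do. As far as these compounds go, whether any group here, such as a longer chain or a chain ending in an amine, can give stronger inhibition than the propyl, cyclopentyl and phenyl amides also remains open.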